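Ethyl to 4-nitrophenyl on the ring nitrogen: an expectation

The compounds below may be only part of what the source reports. "The series", "measured", "known", "first", "only" and "open" are said of these compounds alone.

Measured in a functional assay on aorta with Alpha-1D adrenergic receptor (Rattus norvegicus) as the target; a higher number here means that more compound is needed for the effect, a lower number that less compound is needed:
Compound 1 `Cn1nc(Cc2cccc3ccccc23)c2ccccc2c1=O` gives 14000 nM.
Compound 2 `CCn1nc(Cc2ccc(SC)cc2)c2ccccc2c1=O` gives > 100000 nM, a limit of the assay rather than a number.
Compound 3 `COc1ccc(Cc2nn(-c3ccccc3)c(=O)c3ccccc23)cc1OC` gives > 100000 nM, also a limit.

Compound 2 thus stands at the limit of > 100000 nM in this assay, at which 2 of the 3 values shown sit. No step between the measured compounds is charted, so the pair values are all that is shown. Compound 4 `CSc1ccc(Cc2nn(-c3ccc([N+](=O)[O-])cc3)c(=O)c3ccccc23)cc1` differs from compound 2 in one place: 4-nitrophenyl in place of ethyl on an aromatic nitrogen. Going by the values given here, compound 3, which also carries an aryl group on that nitrogen, sits at the limit, and compound 1 is the only one with a number. For compound 4 no step beyond the scatter is expected in this assay, so it is estimated at 80000 nM (range 20000 nM to 300000 nM). This estimate corresponds to an expected step of an at least 1.2-fold lower number from compound 2 to compound 4 (0.09 log units; that floor lies within the scatter).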

Compound 4, half-maximal effective concentration: > 100000 nM
Compound 4: no number, only a limit (the forecaster's own chance of this, stated with the estimate: 60%); middle value at least 1.2-fold (0.09 log units) from the limit.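

Compound 4 gives > 100000 nM in this assay, a limit of the assay and not a number. Going by these compounds alone, compound 2 also stands at a limit, and no step between compound 2 and compound 4 can be read. The compounds shown leave open whether ethyl or 4-nitrophenyl on the aromatic nitrogen gives the lower number.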